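The source may report more compounds than this note shows. Statements on the series, on what has been measured and on what is new or still open speak of the compounds shown alone.

Compound 1 `CC(C)(C)Sc1c(CC(C)(C)C(=O)O)n(Cc2ccc(Cl)cc2)c2ccc(OCc3ccc4cnccc4n3)cc12` gives 980 nM in a functional assay (blood) for inhibition, with Homo sapiens as the target; a lower number here means a stronger inhibitor, a higher number a weaker inhibitor. Compound 2 `Cc1nc2ccc(COc3ccc4c(c3)c(SC(C)(C)C)c(CC(C)(C)C(=O)O)n4Cc3ccc(Cl)cc3)cc2s1` gives > 3000 nM in this assay, which is a limit and not a number. Compound 3 `C[C@@H](COc1ccc2c(c1)c(SC(C)(C)C)c(CC(C)(C)C(=O)O)n2Cc1ccc(Cl)cc1)c1ccccn1` changes the group on a saturated chain carbon bound to an oxygen on an aromatic ring, with 1-(pyridin-2-yl)ethyl in place of 2-methyl-1,3-benzothiazol-6-yl on a saturated chain carbon bound to an oxygen on an aromatic ring. Among the compounds with values here, the only measured step at this place is an at least 3.0-fold higher number from compound 1 to compound 2 (0.48 log units; beyond the scatter), beyond the scatter, and it came with the loss of nitrogen-bearing six-membered aromatic rings, a ring type that compound 3 regains. A modest move to a lower number is therefore expected, an at least 2.5-fold lower number from compound 2 to compound 3 (0.39 log units; beyond the scatter). For compound 3 the estimated value is 1200 nM, with an expected range of 350 nM to 4000 nM.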

Compound 3, half-maximal inhibitory concentration: 280 nM
Compound 3: the middle estimate sits 4.3-fold (0.63 log units) above what was measured; measured number below the stated range.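

At this place, a group with one aromatic ring can outdo both groups with two: this assay shows an at least 10-fold lower number from compound 2 to compound 3 (1.02 log units; beyond the scatter), and also a 3.5-fold lower number from compound 1 to compound 3 (0.54 log units; beyond the scatter). Among these compounds, then, a second ring in this group is not needed for a lower number. Compound 2 is a limit of the assay and not a number, so the first step gives only a bound: the limit of > 3000 nM in this assay, at which 1 of the 3 values shown sits.

Compound 3 brings a smaller group and a defined stereocentre together, and the compounds shown do not separate the two. Going by these compounds, whether pyridin-2-ylmethyl or 1-phenylethyl would give a similar gain stays open.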